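Replacing the diethylamino group of compound 2

The source may report more compounds than this note shows. Statements on the series, on what has been measured and on what is new or still open speak of the compounds shown alone.

In a functional assay (aorta) with Rattus norvegicus as the target (a lower number here means that less compound is needed, a higher number that more compound is needed for the effect), compound 1 `COc1ccc(-c2nc(/N=C(\N)[N+]3(C)CCCCC3)sc2-c2ccc(OC)cc2)cc1` gives 21 uM and compound 2 `CCN(CC)C(=O)c1nc(-c2ccc(OC)cc2)c(-c2ccc(OC)cc2)s1` gives 14 uM. Compound 2 therefore stands level with compound 1, the only other measured point. Compound 3 `COc1ccc(-c2nc(C(=O)N=C(N)N)sc2-c2ccc(OC)cc2)cc1` keeps the shared core and the carbonyl of compound 2, but the diethylamino group leaves: a group of 4 heavy atoms (1 carbon, 3 nitrogen; no ring) in place of a group of 5 heavy atoms (4 carbon, 1 nitrogen; no ring), on a carbonyl carbon. Going by the values given here, no measured step covers this exact change. The nearest evidence is a 1.5-fold lower number from compound 1 to compound 2 (0.18 log units; within the scatter), a replacement of a different group on an aromatic carbon, and it bears on the present change only indirectly. With that single step inside the scatter, the data give no ground to expect a real shift in this assay. The estimated step is a 1.1-fold higher number from compound 2 to compound 3 (0.06 log units; within the scatter), so none beyond the scatter is expected. For compound 3 the expected value is 16 uM, with an estimated range of 5 uM to 50 uM.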

Compound 3, concentration for half-maximal effect: > 100 uM
Compound 3: no number, only a limit; the forecaster's own chance of this, stated with the estimate: 10%; at least 6.2-fold (0.79 log units) between middle value and limit.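

Going by these compounds alone, on the carbonyl carbon, the change from diethylamino to the entering group of 4 heavy atoms gives in this assay an at least 7.1-fold higher number from compound 2 to compound 3 (0.85 log units; beyond the scatter), so this place is not indifferent to what it carries, whereas the one earlier step, at an aromatic carbon, stayed within the scatter. Compound 3 carries a limit and not a number: the limit of > 100 uM in this assay, at which 1 of the 3 values shown sits. The step measured on the aromatic carbon reads an at least 4.7-fold higher number from compound 1 to compound 3 (0.67 log units; beyond the scatter), and both new steps therefore give only a lower bound on the true size.

The compounds shown do not tell whether the rise in this assay comes with the loss of diethylamino or with the entering group itself. Dimethylamino or a plain amino group on the same carbonyl carbon would separate these two readings.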